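Stability notes: from compound 3 to compound 4

This account rests on a few compounds, and the source may have more. Where it says the series, first, only, none or still open, it means among the compounds named here.

In an ADME assay on microsomes from liver (Mus musculus) for metabolic stability, read by LC-MS, with NADPH named in the record, with a stated time of 60 min, tested at 1 uM, in the absence of a further agent (a lower number here means that less of the compound is left, a higher number that more of the compound is left), compound 1 `COc1ccc(-c2c(C)nc3c(N4CC[C@@H](NC(=O)Oc5cccc(C)c5)C4)cc(C)nn23)cc1OC` gives > 95% as a limit. Compound 2 `COc1ccc(-c2c(C)nc3c(N4CC[C@@H](NS(=O)(=O)C(C)C)C4)cc(C)nn23)cc1OC` gives > 95% as a limit too. Compound 3 `COc1ccc(-c2c(C)nc3c(N4CC[C@@H](NS(=O)(=O)c5ccc(C#N)cc5)C4)cc(C)nn23)cc1OC` gives > 95% as a limit as well, so it stands without a number of its own. The change 4-phenyl-1H-1,2,3-triazol-1-yl in place of ((4-cyanophenyl)sulfonyl)amino on a saturated ring carbon leads to compound 4 `COc1ccc(-c2c(C)nc3c(N4CC[C@@H](n5cc(-c6ccccc6)nn5)C4)cc(C)nn23)cc1OC` with 4-phenyl-1H-1,2,3-triazol-1-yl in place of ((4-cyanophenyl)sulfonyl)amino on a saturated ring carbon. The steps a step that the two limits leave unreadable from compound 1 to compound 3 and a step that the two limits leave unreadable from compound 2 to compound 3 bear on it but give no size, and the limit of > 95% in this assay, at which 3 of the 3 values shown sit, is all the series offers. A small downward step a number at least 5 percentage points lower from compound 3 to compound 4 (that floor lies within the scatter) is expected in this assay and may stay within the scatter. For compound 4 the estimate is 90% with an expected range from 70% to 100% in this assay for now.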

Compound 4, percent of the compound remaining: "unstable" (no number reported)
No number was reported for compound 4; the estimate stays without a comparison.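

For the compounds shown here, compound 4 is recorded in this assay only as unstable, without a number, so no step from compound 3 to compound 4 can be read. As far as these compounds go, how much of compound 4 remains stays open.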